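Thiosemicarbazone aryl swap: hydroxyphenyl to chlorophenyl

The source may report more compounds than this note shows. Statements on the series, on what has been measured and on what is new or still open speak of the compounds shown alone.

This account concerns a small set of thiosemicarbazones built on the core of compound 1 `CC1=CC[C@H](C(C)(C)N=C=S)CC1` and tested in a functional assay on K562 cells (Homo sapiens) for inhibition, read by sulforhodamine B assay, with a stated time of 48 h; on this read-out lower numbers stand for stronger inhibition of growth and higher numbers for weaker inhibition of growth. Compound 1 gives 4000 nM in this assay. Compound 2 `CC1=CC[C@H](C(C)(C)NC(=S)N/N=C/c2ccccc2)CC1` gives 6300 nM, and compound 3 `CC1=CC[C@H](C(C)(C)NC(=S)N/N=C/c2ccccc2O)CC1` gives 800 nM, the lowest number among the three measured compounds. Among the measured compounds shown here, the one single-point step measured so far runs from compound 2 to compound 3 and amounts to a 7.9-fold lower number from compound 2 to compound 3 (0.90 log units; beyond the scatter).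

Compound 4 `CC1=CC[C@H](C(C)(C)NC(=S)N/N=C/c2ccc(Cl)cc2)CC1` differs from compound 3 by 4-chlorophenyl in place of 2-hydroxyphenyl on a carbon with a double bond to nitrogen. The step from compound 2 to compound 3 bears on this change only in part: it shows that adding the hydroxy lowered the number, so taking it away is expected to raise the number again, toward the value of compound 2. For the measured compounds named here, no measured compound carries a chlorine on that ring, so the contribution of the 4-chlorophenyl itself is unknown. For compound 4 the estimated step is therefore a 5.0-fold higher number from compound 3 to compound 4 (0.70 log units; beyond the scatter), and compound 4 is expected to give about 4000 nM in this assay, with a range from 1500 nM to 12000 nM.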

Compound 4, concentration for 50% growth inhibition: 300 nM
Beside the measured number, compound 4's estimate is 13-fold (1.12 log units) above it, outside the stated range (below it).
By their numbers in this assay, from the lowest: compound 4; then compound 3; then compounds 1 and 2 (each within the scatter of the next).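

In this assay, among the compounds shown here, the hydroxy proves not to be the only change on this ring that lowers the number: adding a chloro to the ring gives a 21-fold lower number from compound 2 to compound 4 (1.32 log units; beyond the scatter) and the step counts as large. With 4-chlorophenyl in place of 2-hydroxyphenyl on a carbon with a double bond to nitrogen there is a 2.7-fold lower number from compound 3 to compound 4 (0.43 log units; beyond the scatter) so a group with 0 hydrogen-bond donors and 0 hydrogen-bond acceptors here can go below the hydroxy compound. Nothing measured on these compounds explains why the chlorine gives this result.

As far as these compounds go, whether 4-fluorophenyl, 4-methoxyphenyl or 4-aminophenyl would behave like 4-chlorophenyl remains open. So does the outcome of carrying the hydroxy and the chloro together on one ring.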